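From Methoxycarbonyl to Carboxy: Compound 3 Awaits Measurement

A few compounds are considered here, and "the series" means these few. Any claim that something is new, unique, unknown or untested is made for them only; others in the source may bear on it.

Measured so far:
- compound 1, `CSc1ccc(NC(=O)Nc2cc(C)nc3ccccc23)cc1`: in an ADME assay on Raji cells (Homo sapiens) for cytotoxicity, with a stated time of 72 h (a higher number here means that more compound is needed for the effect, a lower number that less compound is needed), compound 1 gives > 25000 nM, a limit of the assay rather than a number.
- compound 2, `COC(=O)c1ccc(NC(=O)Nc2cc(C)nc3ccccc23)cc1`: in this assay compound 2 gives 17000 nM.

Among the compounds with values here, compound 2 stands as the only numerical value in this assay; the other result is a limit, noted as the limit of > 25000 nM in this assay, at which 1 of the 2 values shown sits. Within the data shown here, the sole measured step, an at least 1.4-fold lower number from compound 1 to compound 2 (0.16 log units; that floor lies within the scatter), concerns the methylsulfanyl position and lies within the scatter.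

Compound 3, `Cc1cc(NC(=O)Nc2ccc(C(=O)O)cc2)c2ccccc2n1`, differs from compound 2 in one place: hydrogen in place of methyl on an oxygen next to a carbonyl group. Among the measured compounds shown here, no measured step touches an oxygen next to a carbonyl group, so nothing recorded bears directly on this change; the step from compound 1 to compound 2 sits elsewhere and was itself within the scatter. Compound 3 is therefore expected to show no step beyond the scatter, estimated as a 1.5-fold higher number from compound 2 to compound 3 (0.17 log units; within the scatter). For compound 3 the estimate is 25000 nM, within a range of 8000 nM to 80000 nM.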

Compound 3, half-maximal effective concentration: > 25000 nM
Compound 3 was reported as a limit (the forecaster's own chance of this, stated with the estimate: 55%); the middle value lies on the limit itself.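

Hydrogen in place of methyl on an oxygen next to a carbonyl group now has a measured step in this assay, which no earlier pair provided: an at least 1.4-fold higher number from compound 2 to compound 3 (0.16 log units; that floor lies within the scatter). As far as these compounds go, compound 3 gives > 25000 nM, which is a limit of the assay and not a number, so the printed floor alone does not establish a change beyond the scatter, and the full size of the step stays unknown. The limit is now shared by compound 1 and compound 3: the limit of > 25000 nM in this assay, at which 2 of the 3 values shown sit.

The step from compound 1 to compound 3 cannot be read, so the carboxy and methylsulfanyl groups cannot be ordered against each other. From the compounds shown here alone, whether a primary amide or an amine in place of the carboxy group would give a number in this assay also stays open.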